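Growth inhibition notes: the step to compound 3

The compounds below may be only part of what the source reports. "The series", "measured", "known", "first", "only" and "open" are said of these compounds alone.

Measured so far:
- compound 1 `CC(=O)c1ccc(NC(=O)Cn2nc(-c3ccc(Cl)cc3)nc2N)cc1`: 16.5%
- compound 2 `C/C(=N/O)c1ccc(NC(=O)Cn2nc(C(F)(F)F)nc2N)cc1`: 23.3%

In a functional assay on MOLT-4 cells (Homo sapiens) for inhibition, read by sulforhodamine B assay, with a stated time of 48 h, tested at 10 uM (a lower number here means less inhibition of growth, a higher number more inhibition of growth at the concentration tested), compound 2 gives 23.3% and compound 1 gives 16.5%, two values within the scatter of each other. With only these two numbers, compound 2 stands level with compound 1.

The next compound is compound 3 `CC(=O)c1ccc(NC(=O)Cn2nc(C(F)(F)F)nc2N)cc1`, not yet measured in this assay. It carries acetyl in place of the group of compound 2 on an aromatic carbon, para to a large group: a group of 3 heavy atoms (2 carbon, 1 oxygen; no ring) in place of a group of 4 heavy atoms (2 carbon, 1 nitrogen, 1 oxygen; no ring), on an aromatic carbon.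

Among the compounds with values here, no measured pair shows this change, so its size rests on little. Compound 1 also carries acetyl and gives 16.5%, so no step beyond the scatter is expected. The estimated step of a number 4.3 percentage points lower from compound 2 to compound 3 (within the scatter) is small and downward. For compound 3 the expected value is 19%, with an estimated range of 6% to 33%.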

Compound 3, percent growth inhibition at one concentration: 7.46%
Compound 3: the middle estimate sits 11.5 percentage points above what was measured; measured number inside the range.
By their numbers in this assay, from the lowest: compounds 3, 1 and 2 (each within the scatter of the next, the first and the last beyond it).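

In this assay, within the data shown here, putting acetyl in place of the group of 4 heavy atoms, on an aromatic carbon para to a large group, gives a number 15.8 percentage points lower from compound 2 to compound 3 (beyond the scatter) and is the first single-place step to lie beyond the scatter, so this position responds to the change. The other single-place change, trifluoromethyl in place of 4-chlorophenyl on an aromatic carbon, gives a number 9 percentage points lower from compound 1 to compound 3 (within the scatter) and stays unresolved with acetyl held fixed. Among these compounds, nothing measured so far accounts for the step at the acetyl position.

The compounds shown leave open what an amine or a carboxylic acid on this aromatic carbon would give. They also leave open whether the step seen with trifluoromethyl holds with 4-chlorophenyl on the core.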